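The source may hold more compounds than are shown below. What is called first, only, known or untested is meant among the compounds shown, and "the series" means these compounds.

Measured compounds:
compound 1, `Cc1cccc(C#CC2=C/C(=N/Oc3cccc(F)n3)CCC2)n1`, 46.8 nM
compound 2, `Fc1cccc(O/N=C2/C=C(C#Cc3ccccn3)CCC2)n1`, 9.15 nM
compound 3, `Fc1cccc(O/N=C2\C=C(C#Cc3ccccn3)CCC2)n1`, 44 nM

In an assay on brain (strain Sprague-Dawley) for displacement of a labelled ligand from metabotropic glutamate receptor 5 (Rattus norvegicus), with a stated time of 45 min (on this read-out lower numbers stand for stronger inhibition and higher numbers for weaker inhibition), compound 2 gives the lowest of the three numbers. From compound 1 to compound 2 the change is a 5.1-fold lower number from compound 1 to compound 2 (0.71 log units; beyond the scatter), and from compound 2 to compound 3 it is a 4.8-fold higher number from compound 2 to compound 3 (0.68 log units; beyond the scatter), a step that rests on the fact that compounds 2 and 3 differ only in the configuration as drawn alone. Compound 4, `FCCCOCO/N=C1/C=C(C#Cc2ccccn2)CCC1`, has not yet been measured. It differs from compound 2 by (3-fluoropropoxy)methyl in place of 6-fluoropyridin-2-yl on an oxygen. Neither of the measured steps touches the group attached to that oxygen: one removes a methyl from an aromatic carbon, the other turns the configuration of the double bond. Going by the values given here, no measured step therefore bears directly on this change, and the expectation must rest on the size of the change itself, in which a ring-bearing group gives way to an open chain. Compound 4 is expected to give a weaker result, with an estimated step of a 22-fold higher number from compound 2 to compound 4 (1.34 log units; beyond the scatter). The value of compound 4 is estimated at 200 nM, within the range 30 nM to 1500 nM.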

Compound 4, inhibition constant: 5.42 nM
Beside the measured number, compound 4's estimate is 37-fold (1.57 log units) above it; the whole stated range lies above it.
By their numbers in this assay, from the lowest: compounds 4 and 2 (each within the scatter of the next); then compounds 3 and 1 (each within the scatter of the next).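

In this assay, the oxygen whose other neighbour is the double-bonded nitrogen accepts (3-fluoropropoxy)methyl in place of 6-fluoropyridin-2-yl with a 1.7-fold lower number from compound 2 to compound 4 (0.23 log units; within the scatter). The earlier compounds shown here left this group unchanged, and this pair now shows that, on this core and with this configuration as drawn, an open chain with no ring can stand in for the aromatic ring without a change beyond the scatter. Nothing available accounts for this result.

The compounds shown leave open whether a longer chain, or a chain ending in an amine or a carboxylic acid, would be accepted on the same oxygen. They also leave open whether the configuration of the double bond matters with the open chain as it does for the pair compound 2 and compound 3.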